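A few compounds are considered here, and "the series" means these few. Any claim that something is new, unique, unknown or untested is made for them only; others in the source may bear on it.

The shared core of compound 1 `O=C(CBr)Nc1ccc(C(=O)/C=C/c2ccc(Cl)cc2)cc1`, compound 2 `O=C(CO[N+](=O)[O-])Nc1ccc(C(=O)/C=C/c2ccc(Cl)cc2)cc1` and compound 3 `O=C(CO[N+](=O)[O-])Nc1ccc(C(=O)/C=C/c2ccco2)cc1` carries a chalcone-type chain joined to an amide. In a functional assay on the whole organism (strain albino) for inhibition, with Rattus norvegicus as the target, read by paw edema, with stated times of 30 min and 3 h, at a dose of 100 mg/kg by the oral route (on this read-out higher numbers stand for more inhibition at the one dose given (going by the name of the read-out) and lower numbers for less inhibition), compound 1 gives 59%, compound 2 gives 69% and compound 3 gives 48%. Compound 2 holds the highest number of the three, though the step of a number 10 percentage points higher from compound 1 to compound 2 (within the scatter) lies within the scatter, while the step of a number 21 percentage points lower from compound 2 to compound 3 (beyond the scatter) is a modest drop. Compound 4 `CC(=O)c1ccc(OCC(=O)Nc2ccc(C(=O)/C=C/c3ccc(Cl)cc3)cc2)cc1` differs from compound 2 by 4-acetylphenyl in place of nitro on an oxygen on a saturated carbon. Within the data shown here, no measured step touches this position, so the expected step of a number 7 percentage points lower from compound 2 to compound 4 (within the scatter) is none beyond the scatter, and compound 4 is estimated to give 62% in this assay, between 45% and 78%.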

Compound 4, a percentage reported as inhibition, in the whole organism at one dose (the size of the read-out at that dose, not a potency): 61%
Beside the measured number, compound 4's estimate is 1 percentage points above it, within the range that was stated.
By their numbers in this assay, from the lowest: compound 3; then compounds 1, 4 and 2 (each within the scatter of the next).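

In this assay, the wider swap at this place, on a saturated chain carbon bound to a carbonyl carbon, still leaves the read-out in place: 4-acetylphenyl in place of nitro gives a number 8 percentage points lower from compound 2 to compound 4 (within the scatter) and 4-acetylphenoxy in place of bromo gives a number 2 percentage points higher from compound 1 to compound 4 (within the scatter) here. Nitrooxy, bromo and 4-acetylphenoxy therefore cannot be told apart, even though 4-acetylphenoxy brings an aromatic ring. No measured evidence explains this result.
Going by these compounds, whether an amine or a carboxylic acid at this place would also hold the number stays open. So does whether 4-acetylphenoxy would do the same with the furan-2-yl group of compound 3.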